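The source may report more compounds than this note shows. Statements on the series, on what has been measured and on what is new or still open speak of the compounds shown alone.

Going by the values given here, in a physicochemical assay for lipophilicity, at pH 7.4 (on this read-out higher numbers stand for higher lipophilicity and lower numbers for lower lipophilicity), compound 2 `CC(C)Oc1ccc(-c2nnc(-c3cncn3C)s2)cc1Cl` gives 5.7, the lower of the two numbers measured so far, and compound 1 `Cc1nc(C)c(-c2nnc(-c3ccc(OC(C)C)c(Cl)c3)s2)s1` gives 7.76. The next structure, compound 3 `CC(C)Oc1ccc(-c2nnc(-c3cn[nH]c3)s2)cc1Cl`, keeps the shared core and alters only the group on an aromatic carbon of a five-membered aromatic ring with 2 nitrogen and 1 sulfur: 1H-pyrazol-4-yl in place of 1-methyl-1H-imidazol-5-yl on an aromatic carbon. In short, 1H-pyrazol-4-yl stands in place of 1-methyl-1H-imidazol-5-yl.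

Among the compounds with values here, only one measured step bears on this change. It altered the group on the same carbon and gave a number 2.06 log units lower from compound 1 to compound 2 (beyond the scatter), a large step beyond the scatter. That step is a weak guide, however, as it involved a different pair of groups. The new pair are both five-membered aromatic rings with 2 hetero atoms and no net charge, but they differ in their counts of heavy atoms and hydrogen-bond donors. Within the data shown here, no measured step tests this exact exchange, so only a small downward move is expected, one that may stay within the scatter, with an estimated a number 0.20 log units lower from compound 2 to compound 3 (within the scatter). For compound 3, the estimated value is 5.5, with an expected range of 4.8 to 6.2.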

Compound 3, distribution coefficient: 5
For compound 3 the middle estimate is 0.50 log units above the measured one; measured number inside the range.
By their numbers in this assay, from the lowest: compound 3; then compound 2; then compound 1.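

At this carbon of the shared core, even two rings of the same general kind can be told apart in this assay: 1H-pyrazol-4-yl in place of 1-methyl-1H-imidazol-5-yl gives a number 0.70 log units lower from compound 2 to compound 3 (beyond the scatter), a smaller move than the earlier swap but still a real one. The earlier compounds shown here showed only what happens on leaving 2,4-dimethyl-1,3-thiazol-5-yl, whereas the whole move from that group to 1H-pyrazol-4-yl now gives a number 2.76 log units lower from compound 1 to compound 3 (beyond the scatter), so the three groups fall into a clear order at this position. The entering group differs in two counts at once, with 5 heavy atoms against 6 and 1 hydrogen-bond donor against 0, and no measurement at hand explains the step.

Which of these two differences goes with the lower number stays open, and 1-methyl-1H-pyrazol-4-yl on the same carbon would help to separate them. As far as these compounds go, how a group of another type, such as an amine or a carboxylic acid, would read at this position also remains unknown.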